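Acetoxy chain on the acetylated core: expected outcome

The source may report more compounds than this note shows. Statements on the series, on what has been measured and on what is new or still open speak of the compounds shown alone.

Measured in an assay on isolated protein (urine) for inhibition of Myeloperoxidase (Homo sapiens), read by spectrophotometry; a higher number here means a weaker inhibitor, a lower number a stronger inhibitor:
- compound 1 `CC(C)n1[nH]c2ccccc2c1=O` gives 660 nM
- compound 2 `CC(=O)OCC(C)n1[nH]c2ccccc2c1=O` gives 2120 nM
- compound 3 `CC(=O)n1c2ccccc2c(=O)n1C(C)C` gives > 10000 nM, which is a limit of the measurement and not a number

Compound 3 thus stands at the limit of this assay, the limit at which (the limit of > 10000 nM in this assay, at which 1 of the 3 values shown sits). For the measured compounds named here, of the three compounds it is the only one without a numerical value, and its true half-maximal inhibitory concentration is only known to lie beyond that limit.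

Compound 4 `CC(=O)OCC(C)n1c(=O)c2ccccc2n1C(C)=O` differs from compound 3 by acetoxy in place of hydrogen on a saturated chain carbon, two bonds along the chain from an aromatic nitrogen. Going by the values given here, two measured steps bear on it. The same change on the unacetylated core is a 3.2-fold higher number from compound 1 to compound 2 (0.51 log units; beyond the scatter), a modest weakening. The acetyl on the aromatic nitrogen, the change that separates compound 3 from compound 1, is an at least 15-fold higher number from compound 1 to compound 3 (1.18 log units; beyond the scatter), a large weakening that already carries compound 3 to the limit.

Applying a modest weakening on top of a limit can only move the number further beyond it, so compound 4 is expected to return a limit again rather than a number in this assay. The estimated step is a step that the limit leaves unreadable from compound 3 to compound 4, in the weaker direction. Compound 4 is therefore estimated at 32000 nM, within the range from 10000 nM to 100000 nM.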

Compound 4, half-maximal inhibitory concentration: > 10000 nM
Compound 4: no number, only a limit (the forecaster's own chance of this, stated with the estimate: 90%); the middle value does not contradict the limit.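

In this assay, the acetyl in place of hydrogen on an aromatic nitrogen also weakens the series when the acetoxy chain is present, giving an at least 4.7-fold higher number from compound 2 to compound 4 (0.67 log units; beyond the scatter). This change has now been seen on two cores, and a limit bounds both readings: the same change on two cores in this assay, an at least 15-fold higher number (1.18 log units; beyond the scatter) from compound 1 to compound 3 and an at least 4.7-fold higher number (0.67 log units; beyond the scatter) from compound 2 to compound 4; the limit leaves it open whether they differ The value of compound 4, > 10000 nM, is a limit of the assay and not a number, so the step from compound 3 cannot be read and the acetoxy change has no measurable size on the acetylated core.

The compounds shown leave open how far compound 3 and compound 4 lie beyond the limit, and so whether the acetyl costs more on one core than on the other. They also leave open whether a methyl in place of the acetyl on the aromatic nitrogen would return a readable number, and whether a hydroxyl or an amine in place of the acetoxy on the saturated chain carbon would avoid the weakening seen with the acetoxy on the unacetylated core.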